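The source may report more compounds than this note shows. Statements on the series, on what has been measured and on what is new or still open speak of the compounds shown alone.

Compound 1, `Cc1cc(NNC(=O)Nc2cc(Cl)nc(Cl)c2)ncc1-c1cnn(C)c1`: in a functional assay on CHO cells for antagonist activity at sphingosine 1-phosphate receptor 2 (Homo sapiens), read by fluorescence and calcium flux, with a stated time of 3 min (on this read-out lower numbers stand for stronger inhibition and higher numbers for weaker inhibition), compound 1 gives 2600 nM.
Compound 2, `Cc1cc(CNC(=O)Nc2cc(Cl)nc(Cl)c2)ncc1-c1cn(C)nc1C`: compound 2 gives 300 nM.
Compound 3, `CCOc1cc(NC(=O)NCc2cc(C)c(-c3cn(C)nc3C)cn2)cc(Cl)n1`: compound 3 gives 40 nM.

Among these three, compound 3 stands at the lowest number, meaning the strongest inhibition. Among the measured compounds shown here, the one step measured in one place is a 7.5-fold lower number from compound 2 to compound 3 (0.88 log units; beyond the scatter), which is ethoxy in place of chloro on an aromatic carbon. For the measured compounds named here, compound 1 and compound 2 differ in more than one place, so their two values show only that compound 1 sits far higher than compound 2.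

Compound 4, `CCOc1cc(NC(=O)NCc2cc(C)c(-c3cn(C)nc3C(F)(F)F)cn2)cc(Cl)n1`, has not been measured. It differs from compound 3 by trifluoromethyl in place of methyl on an aromatic carbon, on the five-membered aromatic ring with two nitrogens, next to the ring nitrogen. Going by the values given here, no measured step touches this ring, and the only step known, from compound 2 to compound 3, concerns a different position. With nothing to go on beyond the structures, no change beyond the scatter is expected, and the estimated step is a 1.3-fold higher number from compound 3 to compound 4 (0.10 log units; within the scatter). Compound 4 is therefore expected to give 50 nM, within a range from 15 nM to 160 nM.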

Compound 4, half-maximal inhibitory concentration: 11000 nM
The estimate for compound 4 lay 220-fold (2.34 log units) below the measured number, and the stated range ends below it.
By their numbers in this assay, from the lowest: compound 3; then compound 2; then compound 1; then compound 4.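

The methyl at this position on the five-membered aromatic ring with 2 nitrogen cannot be swapped freely: in this assay, replacing it with trifluoromethyl gives a 280-fold higher number from compound 3 to compound 4 (2.44 log units; beyond the scatter). Among the compounds shown here, this is far larger than the only earlier step measured in one place, a 7.5-fold lower number from compound 2 to compound 3 (0.88 log units; beyond the scatter), which concerned a different position, so this pyrazole substituent now appears to have a strong influence on the read-out, at least in this pair. No supporting measurement is available to explain why this one change has such a large effect.

The compounds shown leave open how a hydrogen, an ethyl group or a chlorine atom would behave at this position, which could show whether the loss is specific to trifluoromethyl. They also leave open whether the same change would cost as much with chloro in place of the ethoxy group.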